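Isopropoxy for ethyl on the fused core, inhibition in rat

The source may report more compounds than this note shows. Statements on the series, on what has been measured and on what is new or still open speak of the compounds shown alone.

Measured so far:
compound 1 `CCc1cccc2c(=O)c(-c3nn[nH]n3)c[nH]c12`: > 25 mg/kg
compound 2 `COc1ccc2c(O)c(C(=O)O)cnc2c1`: > 100 mg/kg
compound 3 `Cc1ccc2cc(-c3nn[nH]n3)cnc2c1C`: 25 mg/kg

In a functional assay on the whole organism (strain Sprague-Dawley) for inhibition, with Rattus norvegicus as the target (a lower number here means that less compound is needed, a higher number that more compound is needed for the effect), compound 1 gives only a limit, > 25 mg/kg, with no number behind it. Compound 2 also sits at a limit of this assay, > 100 mg/kg. Going by the values given here, compound 3 is the one measured compound with a number, 25 mg/kg. Among the compounds with values here, of the three values shown, one stands at the limit of > 100 mg/kg in this assay, at which 1 of the 3 values shown sits, and one at the limit of > 25 mg/kg in this assay, at which 1 of the 3 values shown sits, so compound 1 can only be placed as not yet active at its tested dose, and no measured step between compounds that differ in one place exists in this assay.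

Compound 4 `CC(C)Oc1cccc2c(=O)c(-c3nn[nH]n3)c[nH]c12` keeps the core of compound 1 and differs in one place: isopropoxy in place of ethyl on an aromatic carbon. With compound 1 known only as a limit, the size of the step in this assay cannot be anchored; no change beyond the usual scatter is expected in either direction, and the estimated step that the limit leaves unreadable from compound 1 to compound 4 is taken as small. Compound 4 is estimated at 40 mg/kg, within 15 mg/kg to 100 mg/kg, with a fair chance that this assay again reports only a limit.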

Compound 4, minimum effective dose: 1.25 mg/kg
Beside the measured number, compound 4's estimate is 32-fold (1.51 log units) above it; measured number below the stated range.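

In this assay, going by these compounds alone, isopropoxy in place of ethyl on an aromatic carbon gives an at least 20-fold lower number from compound 1 to compound 4 (1.30 log units; beyond the scatter), the first step that can be read between compounds differing in one place. Compound 1 gives > 25 mg/kg, which is a limit and not a number. Within the data shown here, the group on this aromatic carbon of the shared core is thus enough on its own to change the dose needed by more than the usual scatter, which the earlier compounds could not show.

Whether the oxygen or the branched chain carries the step stays open, and no measurement shown gives a reason for it. Also open, as far as these compounds go, is how ethoxy, a longer chain such as butoxy, or an amine would fare on the same aromatic carbon.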